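Swapping the Para Substituent: From Trifluoromethoxy to Methoxycarbonyl

This account rests on a few compounds, and the source may have more. Where it says the series, first, only, none or still open, it means among the compounds named here.

Measured so far:
compound 1 `O=C(COc1ccc2c(=O)ccoc2c1)Nc1cccc(NC(=O)c2ccc(F)cc2)c1`, 129 nM
compound 2 `O=C(COc1ccc2c(=O)ccoc2c1)Nc1cccc(NC(=O)c2ccc(OC(F)(F)F)cc2)c1`, 869 nM

Both compounds share one core and differ only in the group on the outer benzene ring. In an assay on isolated protein for inhibition of Rho-associated protein kinase 1 (Homo sapiens), read by scintillation counting, radiometric assay and 33P incorporation, with a stated time of 40 min, in the presence of a further agent that is not named here (a higher number here means a weaker inhibitor, a lower number a stronger inhibitor), compound 1 gives 129 nM, while compound 2 gives 869 nM. Compound 2 therefore stands as the weaker of the two: the step of a 6.7-fold higher number from compound 1 to compound 2 (0.83 log units; beyond the scatter) is modest, yet clearly beyond the scatter.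

Compound 3 `COC(=O)c1ccc(C(=O)Nc2cccc(NC(=O)COc3ccc4c(=O)ccoc4c3)c2)cc1` is the next variation on the same core. Relative to compound 2 the change is methoxycarbonyl in place of trifluoromethoxy on an aromatic carbon.

Among the measured compounds shown here, only one measured step bears on this position, the one from compound 1 to compound 2, and it shows that a larger group at this place weakened inhibition. For the measured compounds named here, no measured compound carries methoxycarbonyl, so the direction for compound 3 rests on little. Going by the values given here, because the only guide is a 6.7-fold higher number from compound 1 to compound 2 (0.83 log units; beyond the scatter), compound 3 is expected to land near compound 2 or somewhat better, with a wide range: the estimated step is a 1.7-fold lower number from compound 2 to compound 3 (0.24 log units; within the scatter). The estimate for compound 3 in this assay is 500 nM, between 150 nM and 1700 nM.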

Compound 3, half-maximal inhibitory concentration: 72 nM
For compound 3 the middle estimate is 6.9-fold (0.84 log units) above the measured one, outside the stated range (below it).
By their numbers in this assay, from the lowest: compounds 3 and 1 (each within the scatter of the next); then compound 2.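

In this assay, the step of a 12-fold lower number from compound 2 to compound 3 (1.08 log units; beyond the scatter) shows that the choice of group at this place, para to a large group, can shift the number strongly, even though methoxycarbonyl, with 4 heavy atoms, and trifluoromethoxy, with 5, are close in that count. The step of a 1.8-fold lower number from compound 1 to compound 3 (0.25 log units; within the scatter) stays within the usual scatter, so these two compounds cannot be put in order, and the single fluorine atom and the much larger methoxycarbonyl group serve about equally well here. The earlier impression that a larger group at this place weakens inhibition therefore does not hold as a general rule: it fits compound 2, but compound 3 goes against it.

Nothing measured here explains why trifluoromethoxy and methoxycarbonyl differ so much, even though the two groups also differ in their counts of hydrogen-bond acceptors and double bonds. From the compounds shown here alone, it remains open how this place would respond to a carboxylic acid, a primary amide or an amine, or to a longer ester such as ethoxycarbonyl, any of which could show whether the result for methoxycarbonyl extends beyond this one group.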